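The source may report more compounds than this note shows. Statements on the series, on what has been measured and on what is new or still open speak of the compounds shown alone.

Compound 2, with structure `O=C1c2ccccc2CCCN1CCN1CCC(c2c[nH]c3ccccc23)CC1`, holds the lowest number of the two measured in an assay on isolated protein for binding affinity to 5-hydroxytryptamine receptor 7 (Homo sapiens) (a lower number here means a stronger inhibitor, a higher number a weaker inhibitor), where compound 2 gives 0.407 nM. Its nearest neighbour is compound 1, with structure `O=C1c2ccccc2CCCN1CCN1CCC(Oc2ccc(F)cc2)CC1`, in which 4-fluorophenoxy sits on the saturated ring carbon; in this assay compound 1 gives 4.47 nM. Among the compounds with values here, the single measured step, an 11-fold lower number from compound 1 to compound 2 (1.04 log units; beyond the scatter), is the only guide available. Compound 3, with structure `O=C1c2ccccc2CCCN1CCN1CCC(n2ccc3ccccc32)CC1`, differs from compound 2 by 1H-indol-1-yl in place of 1H-indol-3-yl on a saturated ring carbon. Within the data shown here, no measured step describes this kind of change, so the expectation rests on the size of the one step above and on the fact that compound 2 stands at the low end of the numbers. Compound 3 is therefore expected to show a modest rise in this assay, a 4.9-fold higher number from compound 2 to compound 3 (0.69 log units; beyond the scatter), with an estimated value of 2 nM and a likely range from 0.5 nM to 8 nM.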

Compound 3, inhibition constant: 2.75 nM
Compound 3: middle estimate off by 1.4-fold (0.14 log units), on the low side; the measured number falls inside the stated range.
By their numbers in this assay, from the lowest: compound 2; then compounds 3 and 1 (each within the scatter of the next).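

In this assay, the point of attachment of the indole on the saturated ring carbon proves to matter: with the same atoms joined differently, the change brings a 6.8-fold higher number from compound 2 to compound 3 (0.83 log units; beyond the scatter) and takes the count of hydrogen-bond donors in the group from 1 to 0. The low number of compound 2 therefore belongs to 1H-indol-3-yl and not to any attached indole, since a 1.6-fold lower number from compound 1 to compound 3 (0.21 log units; within the scatter) leaves 1H-indol-1-yl and 4-fluorophenoxy within the scatter of each other. No evidence is available on what lies behind this step.

The compounds shown leave open whether the attachment point itself or the loss of the hydrogen on the indole nitrogen drives the step. A 1-methyl-1H-indol-3-yl group, which keeps the attachment of compound 2 without that hydrogen, would separate the two.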